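Trifluoromethyl added to a compound at the assay limit

The compounds below may be only part of what the source reports. "The series", "measured", "known", "first", "only" and "open" are said of these compounds alone.

Compound 1, `C/C(=C\c1cc(-c2ccccc2)cs1)C(N)=O`, in a functional assay on T-24 cells (Homo sapiens) for cytotoxicity, read by CCK-8 assay, with a stated time of 24 h (a lower number here means a stronger inhibitor, a higher number a weaker inhibitor), gives > 50000 nM, which is a limit of the assay and not a number.
Compound 2, `C/C(=C\c1cc(-c2ccccc2C)cs1)C(N)=O`, in this assay gives > 50000 nM, likewise a limit.

For the measured compounds named here, compound 1 therefore stands only at a limit, and the sole other measured value does as well, (the limit of > 50000 nM in this assay, at which 2 of the 2 values shown sit). The step from compound 1 to compound 2, methyl in place of hydrogen on an aromatic carbon, is a step that the two limits leave unreadable from compound 1 to compound 2. Compound 3, `C/C(=C\c1cc(-c2ccc(C(F)(F)F)cc2)cs1)C(N)=O`, differs from compound 1 by trifluoromethyl in place of hydrogen on an aromatic carbon. Going by the values given here, no measured step bears readably on this change, so nothing beyond another limit is expected in this assay. Compound 3 is estimated at 50000 nM, between 20000 nM and 150000 nM. That estimate means an expected step of a number no higher from compound 1 to compound 3 (the limit leaves the size open).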

Compound 3, half-maximal inhibitory concentration: > 50000 nM
Compound 3: a limit, no number; the forecaster's own chance of this, stated with the estimate: 85%; the middle value sits exactly at the limit.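

No step can be read from compound 1 to compound 3, since each stands only at a limit in this assay and not at a number: the limit of > 50000 nM in this assay, at which 3 of the 3 values shown sit.

The compounds shown leave open whether any change to the shared core would give a measurable number in this assay at all.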